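The source may hold more compounds than are shown below. What is called first, only, known or untested is meant among the compounds shown, and "the series" means these compounds.

Working notes on the series. The three measured compounds, compound 1 `Oc1cccc(-c2cc(-c3ccc(Cl)cc3)nc(-c3cccs3)c2)c1`, compound 2 `Oc1cccc(-c2cc(-c3ccco3)nc(-c3ccccc3Cl)c2)c1` and compound 3 `Oc1cccc(-c2cc(-c3ccccc3)nc(-c3ccccc3Cl)c2)c1`, share a core that carries a 3-hydroxyphenyl group and differ in the two remaining aromatic substituents. In a functional assay on DU-145 cells (Homo sapiens) for cytotoxicity, read by CCK-8 assay and cell counting, with a stated time of 2 days (on this read-out higher numbers stand for weaker inhibition and lower numbers for stronger inhibition), compound 3 gives 1480 nM, the lowest of the three numbers. Compound 2 gives 1630 nM, and the step of a 1.1-fold lower number from compound 2 to compound 3 (0.04 log units; within the scatter) sits within the scatter, so the two are not distinguishable. For the measured compounds named here, compound 1 gives 11600 nM, the highest number in the set; no single-point step connects it to compound 3, and the two values only show that compound 1 stands well apart.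

Compound 4 `Oc1cccc(-c2cc(-c3cccs3)nc(-c3ccccc3Cl)c2)c1` is not yet measured. The change from compound 3 is thiophen-2-yl in place of phenyl on an aromatic carbon. Going by the values given here, the only measured step that bears on it is the one from compound 2 to compound 3, where furan-2-yl and phenyl at the same place gave numbers within the scatter of each other. Thiophen-2-yl is, like furan-2-yl, a five-membered aromatic ring with one hetero atom, so no step beyond the scatter is expected in this assay. Compound 1 also carries thiophen-2-yl, but its other substituents differ as well, so it does not isolate this change.

For compound 4 in this assay the estimated value is 1600 nM, with an expected range from 700 nM to 3600 nM. The step of a 1.1-fold higher number from compound 3 to compound 4 (0.03 log units; within the scatter) implied by this estimate is expected to stay within the scatter.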

Compound 4, half-maximal inhibitory concentration: 1700 nM
Beside the measured number, compound 4's estimate is 1.1-fold (0.03 log units) below it; low and high end bracket the measured number.
By their numbers in this assay, from the lowest: compounds 3, 2 and 4 (each within the scatter of the next); then compound 1.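

Working notes on the series, continued. In this assay, the place next to the ring nitrogen now holds three different aromatic rings with the 2-chlorophenyl group kept constant, and thiophen-2-yl in place of phenyl gives a 1.1-fold higher number from compound 3 to compound 4 (0.06 log units; within the scatter), while thiophen-2-yl in place of furan-2-yl gives a 1.0-fold higher number from compound 2 to compound 4 (0.02 log units; within the scatter), so none of the three rings can be told apart at this place. Compound 4 also gives compound 1 its first single-place neighbour, and 2-chlorophenyl in place of 4-chlorophenyl gives a 6.8-fold lower number from compound 1 to compound 4 (0.83 log units; beyond the scatter), so the gap that stood unexplained in the earlier set now belongs to this one change on the other aryl group, with the thiophen-2-yl group held constant. No measurement at hand accounts for either the flat response among the three rings or the step between the chlorophenyl groups.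

The compounds shown leave open whether this flat response extends beyond aromatic rings, for instance to an amine such as morpholine or to a carboxylic acid at the same place. They also leave open whether phenyl or furan-2-yl would match thiophen-2-yl when 4-chlorophenyl is the other group, and how a 3-chlorophenyl group would compare.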